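Thiophen-2-yl for Phenyl in a Cytotoxicity Series

This account rests on a few compounds, and the source may have more. Where it says the series, first, only, none or still open, it means among the compounds named here.

In an ADME assay on HepG2 2.2.15 cells (Homo sapiens) for cytotoxicity, read by MTT assay (on this read-out lower numbers stand for higher toxicity in this test and higher numbers for lower toxicity in this test), compound 1 (`COc1ccc(/C=C/C(=O)Oc2ccc(C(C)=O)cc2)cc1`) reports > 3270000 nM as a limit only. Compound 2 (`COc1cccc(/C=C/C(=O)OC[C@H]2O[C@@H](Oc3ccc(C(C)=O)cc3)[C@H](O)[C@@H](O)[C@@H]2O)c1`) likewise reports > 1510000 nM as a limit only. Going by the values given here, compound 3 (`CC(=O)c1ccc(O[C@@H]2O[C@H](COC(=O)c3ccccc3)[C@@H](O)[C@H](O)[C@H]2O)cc1`) stands at 1050000 nM as the only actual number among the three. Compound 4 (`CC(=O)c1ccc(O[C@@H]2O[C@H](COC(=O)c3cccs3)[C@@H](O)[C@H](O)[C@H]2O)cc1`) carries thiophen-2-yl in place of phenyl on a carbonyl carbon. Among the compounds with values here, the one measured step at that carbonyl carbon is an at least 1.4-fold lower number from compound 2 to compound 3 (0.15 log units; that floor lies within the scatter) and it starts from a limit. No step beyond the scatter is therefore expected in this assay for this swap. The step expected is a 1.0-fold higher number from compound 3 to compound 4 (0.02 log units; within the scatter) and it stays within the scatter. Compound 4 is estimated at 1100000 nM with 500000 nM to 2500000 nM as its expected range.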

Compound 4, half-maximal cytotoxic concentration: 1570000 nM
Compound 4: middle estimate off by 1.4-fold (0.15 log units), on the low side; the range from low to high includes it.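

In this assay, going by these compounds alone, the swap gives the first step at this carbonyl carbon that joins two actual numbers: a 1.5-fold higher number from compound 3 to compound 4 (0.17 log units; within the scatter). A five-membered aromatic ring with a sulfur atom can thus take the place of phenyl here without a step beyond the scatter. The step from compound 2 to compound 4 cannot be read, because compound 2 stands at a limit: the limit of > 1510000 nM in this assay, at which 1 of the 4 values shown sits.

Going by these compounds, whether an aminophenyl group or a longer alkyl chain on this carbonyl carbon would give a step beyond the scatter stays open.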